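The compounds below may be only part of what the source reports. "The series", "measured", "known", "first", "only" and "open" are said of these compounds alone.

Working notes on the series.

The shared core is carried by compound 1 `COc1ccc(C(=O)O)cc1OCCCCOc1ccc(C(=O)C(C)C)c(O)c1C` and compound 2 `Cc1c(OCCCCOc2cccc(C(=O)O)c2)ccc(C(=O)CC(C)C)c1O`. In an assay on HEK293 cells for positive allosteric modulation of metabotropic glutamate receptor 2 (Rattus norvegicus), read by thallium flux, with a stated time of 2.5 min (a higher number here means a larger maximal response, a lower number a smaller maximal response), compound 1 gives 66.6%, and in this assay compound 2 gives 84.5%. Among the compounds with values here, compound 2 thus stands highest of the two numbers measured so far; its nearest neighbour is compound 1, whose number lies lower by a gap that is beyond the usual scatter of repeated measurements. Within the data shown here, no pair of measured compounds differs in only one place, so no single step has been isolated.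

Compound 3 `COc1ccc(C(=O)O)cc1OCCCCOc1ccc(C(=O)CC(C)C)c(O)c1C` is not yet measured in this assay. It differs from compound 2 in one place: methoxy in place of hydrogen on an aromatic carbon

Among the measured compounds shown here, with no single-point step available among the measured compounds, the size of the step to compound 3 has to be estimated rather than read off. For compound 3 a modest decrease of the maximal response is expected, of roughly a number 8.5 percentage points lower from compound 2 to compound 3 (within the scatter), a step that may still fall within the scatter. The expected value for compound 3 in this assay is therefore 76%, with a range from 62% to 90%.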

Compound 3, largest response reached (reported as percent of maximum), in percent of the reference or control that the assay uses: 89.7%
For compound 3 the middle estimate is 13.7 percentage points below the measured one; the measured number falls inside the stated range.
By their numbers in this assay, from the lowest: compound 1; then compounds 2 and 3 (each within the scatter of the next).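

In this assay, methoxy in place of hydrogen on an aromatic carbon, ortho to a large group and para to a carboxy group, gives a number 5.2 percentage points higher from compound 2 to compound 3 (within the scatter) and so leaves the maximal response at this position indistinguishable from that with hydrogen. The change on the carbonyl carbon gives the first single-place step beyond the scatter in the series, with isobutyl in place of isopropyl giving a number 23.1 percentage points higher from compound 1 to compound 3 (beyond the scatter) on the shared core, so among these compounds the carbonyl substituent is the one place where a change in response can be read. Nothing measured here gives a reason for either step.

The compounds shown leave open whether the step from isopropyl to isobutyl keeps its size when hydrogen replaces methoxy on the aromatic carbon. From the compounds shown here alone, it is also open how the response changes with a longer chain such as n-pentyl on the carbonyl carbon, or with fluorine or ethoxy at the methoxy position.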